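From carboxy to piperidin-1-yl on the shared core

The compounds below may be only part of what the source reports. "The series", "measured", "known", "first", "only" and "open" are said of these compounds alone.

In an ADME assay for pharmacokinetics, read by LC-MS, in phosphate buffer, with a stated time of 120 min, at pH 7.4, tested at 1 uM, in the presence of a further agent that is not named here (on this read-out higher numbers stand for a longer-lived compound and lower numbers for a shorter-lived compound), compound 1 `CN(C)CC/C=C/C(=O)Nc1ccccc1` gives 7.38 h. Compound 2 `O=C(O)C/C=C/C(=O)Nc1ccccc1` reads > 8.53 h, which is a limit and not a number. Going by the values given here, the one measured step, an at least 1.1-fold higher number from compound 1 to compound 2 (0.06 log units; that floor lies within the scatter), put carboxy in place of (dimethylamino)methyl. Compound 3 `O=C(/C=C/CN1CCCCC1)Nc1ccccc1` goes the other way, with piperidin-1-yl in place of carboxy on a saturated chain carbon bound to a double-bonded chain carbon. Going by that single small step, the expected change, an at least 1.5-fold lower number from compound 2 to compound 3 (0.19 log units; that floor lies within the scatter), is modest and downward in this assay, and may stay within the scatter. For compound 3 the estimated half-life is 5.5 h, with a range of 2 h to 8.5 h.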

Compound 3, half-life: 2.95 h
The estimate for compound 3 lay 1.9-fold (0.27 log units) above the measured number; the range from low to high includes it.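

The half-life at this position, a saturated chain carbon bound to a double-bonded chain carbon, clearly depends on the group placed there. Piperidin-1-yl gives a drop beyond the scatter against both neighbours (an at least 2.8-fold lower number from compound 2 to compound 3 (0.46 log units; beyond the scatter); a 2.5-fold lower number from compound 1 to compound 3 (0.40 log units; beyond the scatter)). Compound 2 carries a limit and not a number, so its step is only a floor: (the limit of > 8.53 h in this assay, at which 1 of the 3 values shown sits).

Still open, from the compounds shown here alone, is whether the ring itself matters, or only the amine nitrogen on this carbon. A dimethylamino or pyrrolidin-1-yl group at the same place would separate those two readings.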